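A few compounds are considered here, and "the series" means these few. Any claim that something is new, unique, unknown or untested is made for them only; others in the source may bear on it.

Compound 3 `CCCCc1cnc(-c2nn(Cc3ccccc3F)c3ncccc23)nc1N` is one of three analogues that share a core and differ only in the group on the aminopyrimidine-type ring of that core. In a functional assay (aorta) with Oryctolagus cuniculus as the target (on this read-out higher numbers stand for weaker inhibition and lower numbers for stronger inhibition), compound 3 gives 218000 nM, the lowest of the two single numbers recorded there. Its nearest neighbour is compound 2 `Cc1cnc(-c2nn(Cc3ccccc3F)c3ncccc23)nc1N`, which in this assay gives 675000 nM; the step of a 3.1-fold lower number from compound 2 to compound 3 (0.49 log units; beyond the scatter) goes beyond the scatter. Compound 1 `Nc1ccnc(-c2nn(Cc3ccccc3F)c3ncccc23)n1` gives 270 nM; 265000 nM (2 entries) in this assay and so has no single number, because the several entries of compound 1 in this assay, 270 nM; 265000 nM (2 entries) shows two entries far apart; it offers no firm anchor.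

Compound 4 `CCCCCc1cnc(-c2nn(Cc3ccccc3F)c3ncccc23)nc1N` differs from compound 3 by methyl in place of hydrogen on a saturated chain carbon, four bonds along the chain from an aromatic carbon, so the chain grows from butyl to pentyl. Among the compounds with values here, the only step that bears on this change is the lengthening step a 3.1-fold lower number from compound 2 to compound 3 (0.49 log units; beyond the scatter), which lowered the number modestly; a further single-carbon extension is expected to move it at most a little in the same direction, possibly not beyond the scatter. The step from compound 3 to compound 4 is therefore estimated as a 1.5-fold lower number from compound 3 to compound 4 (0.16 log units; within the scatter). Compound 4 is expected to give about 150000 nM in this assay, within a range from 50000 nM to 500000 nM.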

Compound 4, half-maximal inhibitory concentration: 200000 nM
Estimate against measurement, compound 4: 1.3-fold (0.12 log units) below, and the stated range covers the measured number.
By their numbers in this assay, from the lowest: compounds 4 and 3 (each within the scatter of the next); then compound 2.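

In this assay, the step of a 1.1-fold lower number from compound 3 to compound 4 (0.04 log units; within the scatter) shows that a methyl in place of hydrogen on a saturated chain carbon, four bonds along the chain from an aromatic carbon, brings no readable difference. The longer comparison, a 3.4-fold lower number from compound 2 to compound 4 (0.53 log units; beyond the scatter), lies beyond the scatter, as does a 3.1-fold lower number from compound 2 to compound 3 (0.49 log units; beyond the scatter). Among these three compounds, the readable difference therefore already appears with the butyl chain of compound 3, and going on to pentyl adds nothing that can be told apart.

From the compounds shown here alone, whether having a chain here matters at all stays open, since compound 1 offers no single number for comparison: the several entries of compound 1 in this assay, 270 nM; 265000 nM (2 entries). Also open, going by these compounds, is how a hexyl chain, a phenyl group or a carboxylic acid in place of the chain would read in this assay.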